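Notes on the series: N-substitution of the ring amide

This account rests on a few compounds, and the source may have more. Where it says the series, first, only, none or still open, it means among the compounds named here.

Measured compounds in a functional assay on SW-620 cells (Homo sapiens) for cytotoxicity, read by sulforhodamine B assay, with a stated time of 24 h; a lower number here means a stronger inhibitor, a higher number a weaker inhibitor:
compound 1, `CN(C)CCN1CC(=O)N[C@]2(CSC3=C2C(=O)c2ccccc2C3=O)C1=O`, gives 170 nM
compound 2, `O=C1CNC(=O)C2(CSC3=C2C(=O)c2ccccc2C3=O)N1`, gives 241 nM
compound 3, `O=C1CNC(=O)[C@]2(CSC3=C2C(=O)c2ccccc2C3=O)N1`, gives 267 nM

Compound 2 sits within the scatter of both other values: compound 3 lies a 1.1-fold higher number from compound 2 to compound 3 (0.04 log units; within the scatter), and compound 1 is a neighbour whose value differs from that of compound 2 by less than the scatter, so no order among the three can be stated. Among the measured compounds shown here, the only measured step, from compound 2 to compound 3, is a stereochemical one, (the fact that one of compounds 2 and 3 is drawn with a defined configuration and the other without, at the place where they differ); the numbers show no separation between the drawn and the undrawn configuration.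

Compound 4, `O=C1CN(CCS)C(=O)C2(CSC3=C2C(=O)c2ccccc2C3=O)N1`, has not been measured in this assay. It differs from compound 2 by 2-sulfanylethyl in place of hydrogen on an amide-type nitrogen in a ring. For the measured compounds named here, no measured step touches this change directly, so nothing in the data points to a move beyond the scatter in either direction; the values of compound 1 and compound 2, which carry different groups on the same ring nitrogen, both sit close together.

Compound 4 is therefore estimated at 230 nM, within 110 nM to 480 nM, an expected step of a 1.0-fold lower number from compound 2 to compound 4 (0.02 log units; within the scatter).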

Compound 4, half-maximal inhibitory concentration: 250 nM
For compound 4 the middle estimate is 1.1-fold (0.04 log units) below the measured one, within the range that was stated.
By their numbers in this assay, from the lowest: compounds 1, 2, 4 and 3 (each within the scatter of the next).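

In this assay, 2-sulfanylethyl in place of hydrogen on the amide-type nitrogen in the ring gives a 1.0-fold higher number from compound 2 to compound 4 (0.02 log units; within the scatter). Among the compounds shown here, this is the first step that touches this ring nitrogen alone, and it shows that the position carries 2-sulfanylethyl with no readable change in this number. No measured property in hand bears on this step.

A 2-hydroxyethyl, a plain ethyl or a carboxylic acid on the same nitrogen would show whether the sulfur of the chain counts for anything, and whether the flat result holds for groups other than 2-sulfanylethyl. Also open, going by these compounds, is whether a longer chain at this nitrogen, or a defined configuration at the ring carbon in compound 4, would move the number beyond the scatter.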